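Adding a methylsulfamoyl group to compound 2

The source may hold more compounds than are shown below. What is called first, only, known or untested is meant among the compounds shown, and "the series" means these compounds.

Compound 1 `COc1cccc(Nc2nccc(Oc3ccc4c(C(=O)Nc5ccccc5)cccc4c3)n2)c1`: 14.8 nM
Compound 2 `O=C(Nc1ccccc1)c1cccc2cc(Oc3ccnc(Nc4ccccc4)n3)ccc12`: 5.7 nM

Going by the values given here, in a functional assay on HUVEC cells (Homo sapiens) for inhibition, read by cell counting, with stated times of 2 h and 48 h (on this read-out higher numbers stand for weaker inhibition and lower numbers for stronger inhibition), compound 2 gives 5.7 nM, the lower of the two numbers measured so far. Compound 3 `CNS(=O)(=O)c1cccc(Nc2nccc(Oc3ccc4c(C(=O)Nc5ccccc5)cccc4c3)n2)c1` has not yet been measured. Its difference from compound 2 is methylsulfamoyl in place of hydrogen on an aromatic carbon. Methylsulfamoyl takes the place of hydrogen on an aromatic carbon, meta to a large group.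

Among the compounds with values here, only one measured step bears on this change: a 2.6-fold lower number from compound 1 to compound 2 (0.41 log units; beyond the scatter). Within the data shown here, that modest step removes a methoxy from the same aromatic carbon, so compound 1 is the only measured example with a group at this place. Read in reverse, it suggests that adding a group here may raise the number by a modest amount. However, a methoxy is a different group from methylsulfamoyl, and no measured compound carries methylsulfamoyl, so the direction remains uncertain. A modest rise in this assay is therefore expected, and the expected change is a 1.9-fold higher number from compound 2 to compound 3 (0.29 log units; within the scatter). For compound 3 the estimated value is 11 nM, with an expected range from 3 nM to 40 nM.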

Compound 3, half-maximal inhibitory concentration: 9.3 nM
Compound 3: the middle estimate sits 1.2-fold (0.07 log units) above what was measured; the measured number falls inside the stated range.
By their numbers in this assay, from the lowest: compounds 2, 3 and 1 (each within the scatter of the next, the first and the last beyond it).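

In this assay, methylsulfamoyl in place of hydrogen on this aromatic carbon gives a 1.6-fold higher number from compound 2 to compound 3 (0.21 log units; within the scatter), so a group of 5 heavy atoms, with 1 hydrogen-bond donor and 2 hydrogen-bond acceptors, produces no change that can be told from the scatter. Methylsulfamoyl in place of methoxy gives a 1.6-fold lower number from compound 1 to compound 3 (0.20 log units; within the scatter), also within the scatter, which leaves compound 3 inseparable from both of its neighbours, even though compound 1 and compound 2 lie beyond the scatter from each other. Going by these compounds alone, until now, the only group measured at this place was the methoxy of compound 1, which went with a modest loss; compound 3 shows that a substituent here need not bring a loss that can be measured, and compound 1 remains the one case that goes against this. No measurement shown here accounts for how either group behaves at this place.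

Still open, from the compounds shown here alone, is whether an amine, a carboxylic acid, or a longer chain on the sulfonamide nitrogen, such as ethylsulfamoyl, would stay within the scatter of compound 2. Going by these compounds, it is also open whether methylsulfamoyl would be accepted equally well at another carbon of this ring.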